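A few compounds are considered here, and "the series" means these few. Any claim that something is new, unique, unknown or untested is made for them only; others in the source may bear on it.

Working notes on the series

Of the compounds shown here, two with a shared core have been measured. Compound 1 `O=C1c2c[n+]([O-])c3ccccc3c2C(=O)c2c1c1ccccc1n2Cc1cn([C@H]2O[C@H](CO)[C@@H](O)[C@H]2O)nn1` and compound 2 `O=C1c2c[n+]([O-])c3ccccc3c2C(=O)c2c1c1ccccc1n2CCCCn1ccnc1` differ in the group on the nitrogen of that core. In a functional assay on SH-SY5Y cells (Homo sapiens) for cytotoxicity, read by MTT assay, with a stated time of 72 h (on this read-out higher numbers stand for weaker inhibition and lower numbers for stronger inhibition), compound 1 gives 1340 nM, while compound 2 gives 130 nM. Compound 2 therefore holds the lowest of the two numbers; the nearest to it is compound 1, with a higher number, and that gap lies beyond the usual scatter.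

The next compound to be measured is compound 3 `O=C1c2c[n+]([O-])c3ccccc3c2C(=O)c2c1c1ccccc1n2Cc1cn(C[C@H](O)CO)nn1`. It differs from compound 2 in one place: 1-(2,3-dihydroxypropyl)-1H-1,2,3-triazol-4-yl in place of 3-(1H-imidazol-1-yl)propyl on a saturated chain carbon bound to an aromatic nitrogen. Compound 3 thus carries a triazole on that chain carbon, as compound 1 does, though with a shorter hydroxylated substituent on it.

With no direct comparison of this kind available, the expectation rests on the two measured values. Because compound 1 gives 1340 nM in this assay and compound 2 gives 130 nM, compound 3 is expected to land between them, closer to compound 2. The step from compound 2 to compound 3 is estimated as a 3.8-fold higher number from compound 2 to compound 3 (0.59 log units; beyond the scatter), a rise beyond the scatter. For compound 3 the estimate is 500 nM, with a range from 180 nM to 1500 nM.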

Compound 3, half-maximal inhibitory concentration: > 1000 nM
Compound 3 gave a limit, no number; the forecaster's own chance of this, stated with the estimate: 3%; middle value at least 2.0-fold (0.30 log units) from the limit.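

The change at this position, 1-(2,3-dihydroxypropyl)-1H-1,2,3-triazol-4-yl in place of 3-(1H-imidazol-1-yl)propyl on a saturated chain carbon bound to an aromatic nitrogen, gives an at least 7.6-fold higher number from compound 2 to compound 3 (0.88 log units; beyond the scatter). Among the compounds shown here, this is the first step between compounds that differ in one place, and it shows that the number responds to the group carried there, with a size beyond the scatter. The size of this step is only a lower bound, as the value for compound 3 is a limit and not a number: the limit of > 1000 nM in this assay, at which 1 of the 3 values shown sits.

The step from compound 1 to compound 3 cannot be read, which leaves 2,3-dihydroxypropyl and 3,4-dihydroxy-5-(hydroxymethyl)oxolan-2-yl on the aromatic nitrogen unordered. For the compounds shown here, the single change from compound 2 to compound 3 replaces the ring, the chain and the hydroxyl groups together, so the part that carries the step remains open, and a butyl chain ending in an unsubstituted 1,2,3-triazole, or one ending in a dimethylamino group, would bear on that question.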